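Swapping the Sulfur Substituent: From Compound 1 to Compound 4

A few compounds are considered here, and "the series" means these few. Any claim that something is new, unique, unknown or untested is made for them only; others in the source may bear on it.

Compound 1 `CCOc1ccc(/C=C(/Sc2ccc(C)cc2)C(=O)c2ccc(Cl)cc2)cc1OC` was tested in a functional assay on DU-145 cells (Homo sapiens) for inhibition, read by trypan blue exclusion, with a stated time of 96 h (a higher number here means a weaker inhibitor of growth, a lower number a stronger inhibitor of growth), where compound 1 gives 25000 nM. Two companions frame it. For the measured compounds named here, compound 3 `CCOc1ccc(/C=C(/Sc2ccc(C)cc2)C(=O)c2ccc(Br)cc2)cc1OC` gives 50000 nM in this assay, and the single change from chloro to bromo moves the number a 2.0-fold higher number from compound 1 to compound 3 (0.30 log units; within the scatter), so compound 1 and compound 3 cannot be told apart here. Compound 2 `COc1ccc(/C=C(/SCc2ccc(F)cc2)C(=O)c2ccc(C(=O)O)cc2)cc1O`, which carries the 4-fluorobenzyl on sulfur together with other differences in both aryl portions, gives 10000 nM, a number beyond the scatter from compound 1 on the lower side; compound 1 thus stands between the other two values.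

Compound 4 `CCOc1ccc(/C=C(/SCc2ccc(F)cc2)C(=O)c2ccc(Cl)cc2)cc1OC` differs from compound 1 in one place: 4-fluorobenzyl in place of 4-methylphenyl on a sulfur. Going by the values given here, no measured pair isolates this exchange. Among the compounds with values here, the only step between single-point neighbours is the one from compound 1 to compound 3, which concerns the halogen and stays within the scatter. Compound 2 shows that a 4-fluorobenzyl on sulfur is compatible with a lower number, but its other changes leave the contribution of the sulfur group alone unresolved.

Compound 4 is therefore expected to sit close to compound 1, with a shift of a 1.3-fold lower number from compound 1 to compound 4 (0.10 log units; within the scatter) that is not expected to exceed the scatter. The estimate for compound 4 in this assay is 20000 nM, with a range from 6000 nM to 60000 nM.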

Compound 4, concentration for 50% growth inhibition: 1000 nM
The estimate for compound 4 lay 20-fold (1.30 log units) above the measured number; the whole stated range lies above it.
By their numbers in this assay, from the lowest: compound 4; then compound 2; then compounds 1 and 3 (each within the scatter of the next).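

In this assay, for the compounds shown here, the group on sulfur proves to be a place where a single exchange counts: 4-fluorobenzyl in place of 4-methylphenyl gives a 25-fold lower number from compound 1 to compound 4 (1.40 log units; beyond the scatter), whereas the only earlier single-place step, a 2.0-fold higher number from compound 1 to compound 3 (0.30 log units; within the scatter), concerned the halogen. With the rest of the core of compound 1 unchanged, the sulfur exchange alone is enough for this large fall in the number, something compound 2 could not show, as it carries other differences in both aryl portions. Nothing among the data given here accounts for the size of this step.

The exchange also alters two things at once, adding a carbon between sulfur and the ring and putting fluoro where methyl stood, so the compounds shown cannot say which of the two carries the step; an unsubstituted benzyl, a 4-methylbenzyl or a 4-fluorophenyl on sulfur would separate them. Going by these compounds, it also remains open whether the same exchange holds with bromo in place of chloro, as in compound 3, and whether a longer chain such as 2-phenylethyl on sulfur would lower the number further.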